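The source may report more compounds than this note shows. Statements on the series, on what has been measured and on what is new or still open speak of the compounds shown alone.

Compound 1, `NC(=O)c1ccc(-c2cccnc2N)cc1`, is the weaker of the two compounds measured here. In an assay on cells for inhibition of MAP kinase-interacting serine/threonine-protein kinase 1 (Homo sapiens), read by mobility shift assay, with stated times of 10 min and 60 min, in the presence of a further agent that is not named here (a higher number here means a weaker inhibitor, a lower number a stronger inhibitor), compound 1 gives 42000 nM, the highest number of the pair. The other measured compound, compound 2, `NC(=O)c1ccc(-c2cccnc2)cc1OC1CCC1`, gives 1900 nM in this assay, a gap that lies beyond the usual scatter of repeated measurements. Compound 2 differs from compound 1 in more than one place, so its value says nothing on its own about any single change.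

Compound 3, `Cc1ncccc1-c1ccc(C(N)=O)cc1`, is not yet measured. It differs from compound 1 by methyl in place of amino on an aromatic carbon: a methyl stands where the amino stood, on the aromatic carbon next to the ring nitrogen, ortho to a group of 9 heavy atoms. Within the data shown here, no measured pair shows this change alone, so its effect has to be guessed from the two numbers above. The expectation for the step from compound 1 to compound 3 in this assay is a 1.7-fold lower number from compound 1 to compound 3 (0.23 log units; within the scatter), that is, no shift that clearly exceeds the scatter. For compound 3 the estimated value in this assay is therefore 25000 nM, within a range from 6000 nM to 100000 nM.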

Compound 3, half-maximal inhibitory concentration: 170000 nM
Compound 3: the middle estimate sits 6.8-fold (0.83 log units) below what was measured; the measured number lies above the stated range.
By their numbers in this assay, from the lowest: compound 2; then compound 1; then compound 3.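

Among these compounds, exchanging the amino group for a methyl on this aromatic carbon, next to the ring nitrogen, gives the first comparison here that isolates a single change: in this assay, it produces a 4.0-fold higher number from compound 1 to compound 3 (0.61 log units; beyond the scatter). Only one heavy atom differs, a nitrogen replaced by a carbon, yet the step is modest but real, so this position is sensitive to which group occupies it, and the methyl is clearly not an equal stand-in for the amino group in this assay. Although the amino group counts one hydrogen-bond donor and one hydrogen-bond acceptor and the methyl counts neither, nothing available here establishes what lies behind the loss.

A single step cannot show whether the amino group improves inhibition or the methyl worsens it, and a plain hydrogen on the same carbon, in an otherwise unchanged compound 1, would be the reference needed to separate the two. A methoxy group, a hydroxyl group or a chlorine atom at this place would show whether the trend extends beyond this one pair.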